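Ring Size on the Amide: Cyclobutyl to Cyclohexyl

A few compounds are considered here, and "the series" means these few. Any claim that something is new, unique, unknown or untested is made for them only; others in the source may bear on it.

Compound 1 `CCCCN1CCc2nc(C#Cc3ccccc3)sc2C1`: in an assay on HEK293 cells for negative allosteric modulation of metabotropic glutamate receptor 5 (Homo sapiens), read by FLIPR, with a stated time of 1 h (a lower number here means a stronger inhibitor, a higher number a weaker inhibitor), compound 1 gives > 10000 nM, which is a limit of the assay rather than a number.
Compound 2 `C(#Cc1nc2c(s1)CN(C1CCCCC1)CC2)c1ccccc1`: in this assay compound 2 gives > 10000 nM, also a limit.
Compound 3 `CC1CC(C(=O)N2CCc3nc(C#Cc4ccccc4)sc3C2)C1`: in this assay compound 3 gives > 10000 nM, again a limit.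

Compound 3 therefore stands at the limit of this assay, and so do its two neighbours: the limit of > 10000 nM in this assay, at which 3 of the 3 values shown sit. None of the three steps among the measured compounds can be read. The change from compound 1 to compound 2 is a step that the two limits leave unreadable from compound 1 to compound 2, the change from compound 1 to compound 3 is a step that the two limits leave unreadable from compound 1 to compound 3, and the change from compound 2 to compound 3 is a step that the two limits leave unreadable from compound 2 to compound 3.

Compound 4 `CC1CCCC(C(=O)N2CCc3nc(C#Cc4ccccc4)sc3C2)C1` keeps the amide and widens the ring on it: 3-methylcyclohexyl in place of 3-methylcyclobutyl on a carbonyl carbon. Within the data shown here, the steps that bear on this position, from compound 1 to compound 3 and from compound 2 to compound 3, only show that putting a (3-methylcyclobutyl)carbonyl group there left the value at the limit, so no direction can be read for the wider ring. The most likely outcome in this assay is that compound 4 also stays at the limit, and the step from compound 3 to compound 4 is expected to be a step that the limit leaves unreadable from compound 3 to compound 4. Compound 4 is estimated at 15000 nM in this assay, with a range from 4000 nM to 60000 nM.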

Compound 4, half-maximal inhibitory concentration: > 10000 nM
Compound 4 ended at the assay's limit (the forecaster's own chance of this, stated with the estimate: 80%); the middle value does not contradict the limit.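

In this assay compound 4 gives > 10000 nM, which is a limit and not a number. The change from compound 3 to compound 4 therefore cannot be read as a step, and all the compounds now share one ceiling: the limit of > 10000 nM in this assay, at which 4 of the 4 values shown sit.

The compounds shown leave open whether ring size on the amide affects inhibition at all, since none of them gives a measurable value.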